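The compounds below may be only part of what the source reports. "The series", "measured", "known", "first", "only" and "open" are said of these compounds alone.

Measured so far in an ADME assay on microsomes from liver (Rattus norvegicus) for metabolic stability, using NADPH, with a stated time of 10 min (a lower number here means that less of the compound is left, a higher number that more of the compound is left), are three compounds:

- compound 1 `NCCCCN(C[C@@H]1Cc2ncccc2CN1)[C@H]1CCCc2cccnc21` with 55% remaining
- compound 2 `CN(C[C@H]1Cc2ncccc2CN1)[C@H]1CCCc2cccnc21` with 7% remaining
- compound 3 `CN(C[C@@H]1Cc2ncccc2CN1)[C@H]1CCCc2cccnc21` with 1% remaining

Compound 2 at 7% lies at the low end of these numbers, level with compound 3. The step there is a number 6 percentage points lower from compound 2 to compound 3 (within the scatter) and the fact that compounds 2 and 3 differ only in the configuration as drawn is the only structural difference in that pair. Only compound 1 stands clearly higher.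

Compound 4 `NC(=O)NC/C=C/CN(C[C@H]1Cc2ncccc2CN1)[C@H]1CCCc2cccnc21` is reached from compound 2 through a group of 7 heavy atoms (4 carbon, 2 nitrogen, 1 oxygen; no ring) in place of a hydrogen atom, on a saturated chain carbon bound to an amine nitrogen and is not yet measured. The closest measured precedent is a number 54 percentage points lower from compound 1 to compound 3 (beyond the scatter) and this large step, read in reverse, links a chain at this carbon with much more compound remaining. For the measured compounds named here, the configuration step was small, so that precedent is expected to carry over to compound 2, although the entering chain is a different one and only a single precedent exists.

A large rise is therefore expected, and the estimated change is a number 33 percentage points higher from compound 2 to compound 4 (beyond the scatter) in this assay. For compound 4 the estimate is 40% with an expected range from 15% to 65% on repeat measurement.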

Compound 4, percent of the compound remaining: 1%
Beside the measured number, compound 4's estimate is 39 percentage points above it; the whole stated range lies above it.
By their numbers in this assay, from the lowest: compounds 3, 4 and 2 (each within the scatter of the next); then compound 1.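

Putting a group of 7 heavy atoms (4 carbon, 2 nitrogen, 1 oxygen; no ring) in place of a hydrogen atom, on a saturated chain carbon bound to an amine nitrogen, leaves this assay within the scatter, with a number 6 percentage points lower from compound 2 to compound 4 (within the scatter). A chain at this place therefore does not by itself go with more compound remaining. The large step with 3-aminopropyl, a number 54 percentage points lower from compound 1 to compound 3 (beyond the scatter), is so far the only one of its size, and compound 4 goes against any reading of it as a general effect of a chain here.

The two chains stand on compounds of different configuration as drawn, so the shown compounds do not separate the entering group from that configuration. Going by these compounds, how a 4-aminobutyl chain or a chain ending in a carboxylic acid would read at this place also stays open.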